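The source may report more compounds than this note shows. Statements on the series, on what has been measured and on what is new or still open speak of the compounds shown alone.

Measured in an assay on isolated protein for inhibition of Fatty-acid amide hydrolase 1 (Homo sapiens), read by fluorescence, with a stated time of 30 min; on this read-out higher numbers stand for weaker inhibition and lower numbers for stronger inhibition:
- compound 1 `CCOC(=O)c1cc(-c2cccc(OC(=O)NC3CCCCC3)c2)n(C)n1` gives 303 nM
- compound 2 `CCOC(=O)c1cc(-c2cccc(OC(=O)NC3CCCCC3)c2)n(-c2ccc(OC)cc2)n1` gives 103 nM
- compound 3 `CCOC(=O)c1cc(-c2cccc(OC(=O)NC3CCCCC3)c2)n(-c2ccc(C(F)(F)F)cc2)n1` gives 132 nM

Compound 3 holds the second highest number of the three. Its nearest neighbour is compound 2, with a 1.3-fold higher number from compound 2 to compound 3 (0.11 log units; within the scatter); its furthest is compound 1, with a 2.3-fold lower number from compound 1 to compound 3 (0.36 log units; beyond the scatter). Compound 3 and compound 2 therefore cannot be ordered against each other, while both sit clearly apart from compound 1.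

The next compound is compound 4 `CCOC(=O)c1cc(-c2cccc(OC(=O)NC3CCCCC3)c2)n(Cc2ccccc2)n1`. Relative to compound 3 the change is benzyl in place of 4-(trifluoromethyl)phenyl on an aromatic nitrogen.

Among the measured compounds shown here, two measured steps bear on substitution at this nitrogen: a 2.9-fold lower number from compound 1 to compound 2 (0.47 log units; beyond the scatter) and a 2.3-fold lower number from compound 1 to compound 3 (0.36 log units; beyond the scatter), both modest and both in the direction of lower numbers when a phenyl group replaces methyl. The comparison a 1.3-fold higher number from compound 2 to compound 3 (0.11 log units; within the scatter) shows that the group on that phenyl ring made no difference beyond the scatter. Benzyl is neither methyl nor a directly attached phenyl, so the expected outcome is a number between those of compound 1 and compound 3, most likely without a step beyond the scatter.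

The estimate for compound 4 in this assay is 180 nM, within 80 nM to 400 nM, which is expected to correspond to a 1.4-fold higher number from compound 3 to compound 4 (0.13 log units; within the scatter).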

Compound 4, half-maximal inhibitory concentration: 70 nM
Compound 4: middle estimate off by 2.6-fold (0.41 log units), on the high side; measured number outside the range, below it.
By their numbers in this assay, from the lowest: compounds 4, 2 and 3 (each within the scatter of the next); then compound 1.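

Benzyl is the first group on this aromatic nitrogen that reaches it through a saturated chain carbon rather than a directly attached ring, and adding phenyl to the methyl of compound 1 gives a step beyond the scatter (a 4.3-fold lower number from compound 1 to compound 4 (0.64 log units; beyond the scatter)), in the same direction as the two directly attached aryl groups. Compound 4 cannot be ordered against either of those aryl compounds, since a 1.9-fold lower number from compound 3 to compound 4 (0.28 log units; within the scatter) and a 1.5-fold lower number from compound 2 to compound 4 (0.17 log units; within the scatter) both stay within the scatter, so among the compounds shown benzyl, 4-methoxyphenyl and 4-(trifluoromethyl)phenyl read alike and compound 1 alone stands apart. No measurement at hand accounts for this result.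

The compounds shown leave open how a longer chain such as phenylethyl, or a benzyl whose ring carries an amine or a carboxylic acid, would read in this assay. They also leave open whether the same reading at this nitrogen holds when the ethoxycarbonyl group gives way to a carboxylic acid or an amide.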